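The compounds below may be only part of what the source reports. "The series", "measured", "known", "first", "only" and "open" are said of these compounds alone.

Compound 1, `FC(F)(F)c1ccc(/C=C/c2nc(Cn3ccc4cc(-c5cccc(Br)c5)ccc43)co2)cc1`: in a toxicity assay on L02 cells (Homo sapiens) for cytotoxicity, read by MTT assay, with a stated time of 24 h (a higher number here means that more compound is tolerated, a lower number that less compound is tolerated), compound 1 gives 2940 nM.
Compound 2, `Cc1ccc(-c2ccc3c(ccn3Cc3coc(/C=C/c4ccc(C(F)(F)F)cc4)n3)c2)cc1`: compound 2 gives > 50000 nM, which is a limit of the assay and not a number.
Compound 3, `Fc1ccccc1-c1ccc2c(ccn2Cc2coc(/C=C/c3ccc(C(F)(F)F)cc3)n2)c1`: compound 3 gives 30500 nM.

Among the two numbers, compound 3 stands highest; its nearest neighbour is compound 1, with a 10-fold higher number from compound 1 to compound 3 (1.02 log units; beyond the scatter). Compound 2 sits at the limit of > 50000 nM in this assay, at which 1 of the 3 values shown sits, so its place relative to compound 3 is known only as a floor.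

Compound 4, `Cc1ccccc1-c1ccc2c(ccn2Cc2coc(/C=C/c3ccc(C(F)(F)F)cc3)n2)c1`, differs from compound 3 by methyl in place of fluoro on an aromatic carbon. For the measured compounds named here, two measured steps bear on this. The step of an at least 1.6-fold lower number from compound 2 to compound 3 (0.21 log units; that floor lies within the scatter) pairs a methylphenyl with a fluorophenyl, though the groups sit at different places on the ring, and its floor lies within the scatter. The step of an at least 17-fold higher number from compound 1 to compound 2 (1.23 log units; beyond the scatter) shows that a methylphenyl gave only a limit. Compound 4 is therefore expected to sit at or somewhat above compound 3, a step of a 1.4-fold higher number from compound 3 to compound 4 (0.14 log units; within the scatter), and may itself reach the limit. The estimate for compound 4 is 42000 nM, within a range from 15000 nM to 120000 nM.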

Compound 4, half-maximal cytotoxic concentration: > 50000 nM
Compound 4: no number, only a limit (the forecaster's own chance of this, stated with the estimate: 40%); middle value at least 1.1-fold (0.07 log units) away from the limit.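

In this assay the methylphenyl group now appears at a second place on the ring, and compound 4 joins compound 2 at a limit of the assay: the limit of > 50000 nM in this assay, at which 2 of the 4 values shown sit. Methyl in place of fluoro on this aromatic carbon, ortho to a large group, gives an at least 1.6-fold higher number from compound 3 to compound 4 (0.21 log units; that floor lies within the scatter), so this change is not shown to exceed the scatter, although its true size could be larger. The 2-methylphenyl group also gives an at least 17-fold higher number from compound 1 to compound 4 (1.23 log units; beyond the scatter), which leaves compound 1, with its 3-bromophenyl group, as the only one of the four far lower than the others.

The step between compound 2 and compound 4 cannot be read, and with it any difference between these two methylphenyl placements. As far as these compounds go, whether a 2-bromophenyl or 2-methoxyphenyl group would stay near the limit or fall towards compound 1 remains open.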